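The compounds below may be only part of what the source reports. "The series", "measured", "known", "first", "only" and "open" are said of these compounds alone.

The study compares four compounds in a functional assay on KB cells (Homo sapiens) for antiproliferative activity, read by MTT assay, with a stated time of 72 h; a higher number here means a weaker inhibitor, a lower number a stronger inhibitor. Compound 1 `COc1ccc(-c2sc(C(=O)O)cc2-c2cc(OC)c(OC)c(OC)c2)cc1[N+](=O)[O-]` bears a nitro group and a carboxylic acid; in this assay compound 1 gives 35900 nM. Compound 2 `COc1ccc(-c2sc(C(=O)O)cc2-c2cc(OC)c(OC)c(OC)c2)cc1OCc1ccccc1` differs from it in one place, (benzyloxy in place of nitro on an aromatic carbon). For compound 2 this assay reports only a limit, > 100000 nM. The measured step is therefore an at least 2.7-fold higher number from compound 1 to compound 2 (0.44 log units; beyond the scatter), and its size is bounded by the limit of > 100000 nM in this assay, at which 1 of the 3 values shown sits. Compound 3 `CCOC(=O)c1cc(-c2ccc(OC)c([N+](=O)[O-])c2)c(-c2cc(OC)c(OC)c(OC)c2)s1` carries an ethyl ester instead of the acid; in this assay compound 3 gives 24000 nM, a value within the usual scatter of that of compound 1, so no order between these two is claimed. The difference between the core of compound 3 and the core of compound 1 is not broken down here. Compound 4 `CCOC(=O)c1cc(-c2ccc(OC)c(OCc3ccccc3)c2)c(-c2cc(OC)c(OC)c(OC)c2)s1` has not yet been measured and differs from compound 3 by benzyloxy in place of nitro on an aromatic carbon, the same change as that made between compound 1 and compound 2, at the same place. The expected step is a 3.3-fold higher number from compound 3 to compound 4 (0.52 log units; beyond the scatter), resting on the measured step of an at least 2.7-fold higher number from compound 1 to compound 2 (0.44 log units; beyond the scatter). Compound 4 is estimated at 80000 nM, between 30000 nM and 300000 nM, with a fair chance that this assay reports only a limit.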

Compound 4, half-maximal inhibitory concentration: > 100000 nM
Compound 4: no number, only a limit; the forecaster's own chance of this, stated with the estimate: 50%; at least 1.2-fold (0.09 log units) between middle value and limit.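

In this assay compound 4 gives > 100000 nM, which is a limit of the assay and not a number. The change of nitro to benzyloxy gives an at least 4.1-fold higher number from compound 3 to compound 4 (0.61 log units; beyond the scatter), so on the core of compound 3 it moves the number in the same direction as on the core of compound 1, and the direction of the step carries over in these two pairs: the same change on two cores in this assay, an at least 2.7-fold higher number (0.44 log units; beyond the scatter) from compound 1 to compound 2 and an at least 4.1-fold higher number (0.61 log units; beyond the scatter) from compound 3 to compound 4; the limit leaves it open whether they differ. What this does not show is how large either step really is, or whether the change costs more on one core than on the other, because compound 2 and compound 4 both end at a limit rather than at a number: the limit of > 100000 nM in this assay, at which 2 of the 4 values shown sit.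

The compounds shown leave open how an amine, a hydroxyl or a short ether such as ethoxy would read in this assay at the place held by nitro and benzyloxy. They also leave open whether the step would hold on a core bearing an amide in place of the carboxylic acid or the ethyl ester.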